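Replacing (phenylsulfanyl)methyl with carboxy on the shared core

The source may hold more compounds than are shown below. What is called first, only, known or untested is meant among the compounds shown, and "the series" means these compounds.

- compound 1 `CC(C)n1nc(-c2cccnc2)c2ccccc2c1=O` gives 3090 nM
- compound 2 `O=C(c1cccs1)n1nc(-c2cccnc2)c2ccccc2c1=O` gives 12300 nM
- compound 3 `O=c1c2ccccc2c(-c2cccnc2)nn1CCSc1ccccc1` gives 9120 nM

These numbers come from a functional assay (trachea) with Cavia porcellus as the target; a lower number here means a stronger inhibitor, a higher number a weaker inhibitor. There, compound 3 lies within the scatter of compound 2, and the number for both is higher than that of compound 1, beyond the scatter.

Compound 4 `O=C(O)Cn1nc(-c2cccnc2)c2ccccc2c1=O` has carboxy in place of (phenylsulfanyl)methyl on a saturated chain carbon bound to an aromatic nitrogen.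

For the measured compounds named here, only one measured step bears on this change, and only indirectly. It is a 4.0-fold higher number from compound 1 to compound 2 (0.60 log units; beyond the scatter), a modest move made directly on the aromatic nitrogen. Going by the values given here, no measured compound carries carboxy, so the direction of any move in this assay remains open, and no step beyond the scatter is expected. The estimated change is a 1.3-fold higher number from compound 3 to compound 4 (0.12 log units; within the scatter).

For compound 4 the expected value is 12000 nM, with an estimated range of 3000 nM to 50000 nM.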

Compound 4, half-maximal inhibitory concentration: > 100000 nM
Compound 4 gave a limit, no number; the forecaster's own chance of this, stated with the estimate: 15%; at least 8.3-fold (0.92 log units) between middle value and limit.
By their numbers in this assay, from the lowest: compound 1; then compounds 3 and 2 (each within the scatter of the next). At a limit, above all of these: compound 4.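

In this assay compound 4 gives > 100000 nM, which is a limit of the assay and not a number. The swap of (phenylsulfanyl)methyl for carboxy gives an at least 10-fold higher number from compound 3 to compound 4 (1.04 log units; beyond the scatter), and the other two comparisons give an at least 8.1-fold higher number from compound 2 to compound 4 (0.91 log units; beyond the scatter) and an at least 32-fold higher number from compound 1 to compound 4 (1.51 log units; beyond the scatter). Substitution on this aromatic nitrogen therefore does more than the earlier 4.0-fold higher number from compound 1 to compound 2 (0.60 log units; beyond the scatter) suggested: compound 1, compound 2 and compound 3 all gave numbers, and only compound 4, with carboxy, reached the limit.

The compounds shown do not separate the arrival of carboxy from the departure of (phenylsulfanyl)methyl, and the true size of each step stays unknown. A methyl ester or a primary amide on the saturated chain carbon, or a longer chain ending in a carboxylic acid, would bear on that question.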